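Halogen change on the aryl group of compound 3

A few compounds are considered here, and "the series" means these few. Any claim that something is new, unique, unknown or untested is made for them only; others in the source may bear on it.

Values in an ADME assay on microsomes from liver (Rattus norvegicus) for metabolic stability, read by LC-MS, using NADPH, at 37 degrees C; a higher number here means that the compound lasts longer, a lower number that the compound disappears faster:
- compound 1 `Cc1cc(C)c(-c2nc(CN3CCC(C(=O)NCCCN4C[C@H](C)C[C@H](C)C4)CC3)c(C)o2)c(C)c1`: > 0.5 h (a limit of the assay)
- compound 2 `Cc1oc(-c2ccc(Cl)cc2)nc1CN1CCC(C(=O)NCCCN2C[C@H](C)C[C@H](C)C2)CC1`: > 0.5 h (a limit of the assay)
- compound 3 `Cc1oc(-c2c(F)cccc2F)nc1CN1CCC(C(=O)NCCCN2C[C@H](C)C[C@H](C)C2)CC1`: 0.35 h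

Only compound 3 has an actual number in this set, 0.35 h. The other two entries are not numbers: the limit of > 0.5 h in this assay, at which 2 of the 3 values shown sit.

Compound 4 `Cc1oc(-c2c(Cl)cccc2Br)nc1CN1CCC(C(=O)NCCCN2C[C@H](C)C[C@H](C)C2)CC1` has 2-bromo-6-chlorophenyl in place of 2,6-difluorophenyl, on an aromatic carbon of a five-membered aromatic ring with 1 nitrogen and 1 oxygen: 2-bromo-6-chlorophenyl in place of 2,6-difluorophenyl on an aromatic carbon.

The measured steps that bear on this change all alter the same aryl group. In this assay they show an at least 1.4-fold lower number from compound 1 to compound 3 (0.15 log units; that floor lies within the scatter) and an at least 1.4-fold lower number from compound 2 to compound 3 (0.15 log units; that floor lies within the scatter), and both floors lie within the scatter. The third is a step that the two limits leave unreadable from compound 1 to compound 2. None of them swaps these halogens directly, so they give no firm direction for the change.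

The expectation therefore starts from compound 3 at 0.35 h, with no shift beyond the scatter in either direction. The estimated step is no change at the digits printed from compound 3 to compound 4 (within the scatter). Compound 4 is expected at 0.35 h, with an estimated range from 0.18 h to 0.7 h.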

Compound 4, half-life: 0.0233 h
Estimate against measurement, compound 4: 15-fold (1.18 log units) above; measured number outside the range, below it.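

In this assay, the aryl group on the shared core turns out to respond strongly to a change of halogens: 2-bromo-6-chlorophenyl in place of 2,6-difluorophenyl gives a 15-fold lower number from compound 3 to compound 4 (1.18 log units; beyond the scatter). The same group gives an at least 21-fold lower number from compound 2 to compound 4 (1.33 log units; beyond the scatter) against 4-chlorophenyl and an at least 21-fold lower number from compound 1 to compound 4 (1.33 log units; beyond the scatter) against 2,4,6-trimethylphenyl, and these two steps are floors set by a limit of the assay: the limit of > 0.5 h in this assay, at which 2 of the 4 values shown sit. Earlier steps at this position had shown only floors within the scatter, whereas compound 4 now has steps beyond the scatter to all three other compounds and is the shortest-lived of the four.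

The compounds shown do not separate the bromine from the chlorine, so 2,6-dichlorophenyl and 2-bromo-6-fluorophenyl would be the groups that tell which halogen goes with the large step. As far as these compounds go, the step between compound 1 and compound 2 cannot be read, as both entries are limits, and it remains open whether the step at this position keeps its size with an amine or a longer chain elsewhere on the core.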